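Swapping the aryl group on the pyridine-free core of compound 1

The compounds below may be only part of what the source reports. "The series", "measured", "known", "first", "only" and "open" are said of these compounds alone.

Compound 1 `COc1ccc(-c2nc(C(F)(F)F)ccc2CNC(=O)C(C)c2ccc(NS(C)(=O)=O)c(F)c2)cc1F` stands lowest of the two measured numbers: in an assay on CHO cells for antagonist activity at transient receptor potential cation channel subfamily V member 1 (Homo sapiens), read by FLIPR (on this read-out lower numbers stand for stronger inhibition and higher numbers for weaker inhibition), compound 1 gives 4.2 nM. Among the compounds with values here, its only measured neighbour is compound 2 `CC(C(=O)NCc1ccc(C(F)(F)F)nc1Cc1ccccc1)c1ccc(NS(C)(=O)=O)c(F)c1`, which in this assay gives 141 nM. Within the data shown here, the single measured step, a 34-fold higher number from compound 1 to compound 2 (1.53 log units; beyond the scatter), shows that exchanging the 3-fluoro-4-methoxyphenyl for a group that sets the phenyl off the core by a carbon costs a great deal of potency.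

Compound 3 `CC(C(=O)NCc1ccc(C(F)(F)F)nc1CCc1ccc(F)cc1)c1ccc(NS(C)(=O)=O)c(F)c1` carries a related change at the same aromatic carbon: 2-(4-fluorophenyl)ethyl in place of 3-fluoro-4-methoxyphenyl on an aromatic carbon. The entering 2-(4-fluorophenyl)ethyl again removes the 3-fluoro-4-methoxyphenyl and places an aromatic ring further out from the core, so the step from compound 1 to compound 2 is the one that bears on it, and that step was large and beyond the scatter. Compound 3 is therefore expected to show a large weakening of the same kind, a 48-fold higher number from compound 1 to compound 3 (1.68 log units; beyond the scatter). In this assay compound 3 is estimated at 200 nM, with a likely range from 60 nM to 700 nM.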

Compound 3, inhibition constant: 1.8 nM
Estimate against measurement, compound 3: 110-fold (2.05 log units) above, outside the stated range (below it).
By their numbers in this assay, from the lowest: compound 3; then compound 1; then compound 2.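

In this assay, the position next to the ring nitrogen accepts 2-(4-fluorophenyl)ethyl in place of 3-fluoro-4-methoxyphenyl with a gain rather than a loss (a 2.3-fold lower number from compound 1 to compound 3 (0.37 log units; beyond the scatter)), so an aromatic ring held off the core by a saturated chain is compatible with strong inhibition here, and compound 3 is the strongest of the three. The large gap to the benzyl compound (a 78-fold lower number from compound 2 to compound 3 (1.89 log units; beyond the scatter)) shows that the loss seen with compound 2 does not extend to every group that sets an aromatic ring off the core, although this step changes both the chain and the ring fluorine at once and cannot divide the gain between them. Nothing measured here accounts for either step.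

Still open, as far as these compounds go, is how much of the gain belongs to the fluorine, which a plain 2-phenylethyl group at this position would separate from the effect of the chain. Equally open, from the compounds shown here alone, is whether the aromatic ring is needed at all, or whether a 2-cyclohexylethyl group, a longer chain or a chain ending in an amine would serve as well.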